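Series notes: return from phenoxymethyl to benzylethyl amide

The compounds below may be only part of what the source reports. "The series", "measured", "known", "first", "only" and "open" are said of these compounds alone.

Three compounds of the shared core have numbers in an assay on HEK293 cells for displacement of a labelled ligand from Melanocortin receptor 4 (Homo sapiens); a higher number here means a weaker inhibitor, a lower number a stronger inhibitor. Compound 1 `Cc1ccc(CC(C)C(=O)N2CCN(c3ccc(C(F)(F)F)cc3[C@@H](N)CC(C)C)CC2)cc1C` gives 240 nM; compound 2 `COc1ccc(OCC(=O)N2CCN(c3ccc(C(F)(F)F)cc3[C@@H](N)CC(C)C)CC2)cc1` gives 3800 nM; compound 3 `COc1cc(Cl)ccc1C[C@@H](C)C(=O)N1CCN(c2ccc(C)cc2[C@@H](N)CC(C)C)CC1` gives 8.1 nM. Compound 2 stands highest of the three, with compound 1 nearest and compound 3 furthest.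

Compound 4 `Cc1cc(Cl)ccc1CC(C)C(=O)N1CCN(c2ccc(C(F)(F)F)cc2[C@@H](N)CC(C)C)CC1` is not yet measured. It differs from compound 2 as follows: 1-(4-chloro-2-methylbenzyl)ethyl in place of (4-methoxyphenoxy)methyl on a carbonyl carbon. Going by the values given here, the one step that bears on this is the one between compound 1 and compound 2, a 16-fold higher number from compound 1 to compound 2 (1.20 log units; beyond the scatter), which runs the opposite way, from a benzylethyl amide to the phenoxymethyl amide. Compound 4 carries a benzylethyl amide of the kind seen in compound 1 and compound 3, so the step to it is expected to reverse that change in direction and to be of similar size in this assay. On this basis compound 4 is estimated at 150 nM, within 40 nM to 600 nM, which means an expected step of a 25-fold lower number from compound 2 to compound 4 (1.40 log units; beyond the scatter).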

Compound 4, inhibition constant: 38 nM
The estimate for compound 4 lay 3.9-fold (0.60 log units) above the measured number; measured number outside the range, below it.
By their numbers in this assay, from the lowest: compound 3; then compound 4; then compound 1; then compound 2.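

In this assay, going by these compounds alone, the 1-(4-chloro-2-methylbenzyl)ethyl group on the carbonyl carbon gives a 100-fold lower number from compound 2 to compound 4 (2.00 log units; beyond the scatter) and confirms that a benzylethyl amide can restore binding in the trifluoromethyl-bearing compounds, which the single earlier step had only suggested in the opposite direction. The benzylethyl amide alone does not set the number: 4-chloro-2-methylphenyl in place of 3,4-dimethylphenyl gives a 6.3-fold lower number from compound 1 to compound 4 (0.80 log units; beyond the scatter) and is beyond the scatter. Within the data shown here, the aryl substituents on this chain therefore matter, at least in this pair, and compound 1 and compound 4 are the only two compounds that show it.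

The compounds shown leave open whether the chlorine of compound 4 could be replaced by a nitrile or a bromine, or its methyl by a methoxy group, with the rest of the molecule unchanged. No measurement available explains either step.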